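Methoxy Added to the Phenyl Ring of Compound 2

The source may hold more compounds than are shown below. What is called first, only, known or untested is meant among the compounds shown, and "the series" means these compounds.

Of the compounds shown here, two of a shared core have been measured in a functional assay on DLA cells (Mus musculus) for cytotoxicity, read by trypan blue exclusion, with a stated time of 48 h; a lower number here means a stronger inhibitor, a higher number a weaker inhibitor. Compound 1 `COc1ccc(-c2csc(NC(=O)COc3ccc(C(=O)c4ccc(C)cc4)cc3C)n2)cc1` gives 16000 nM in this assay. Compound 2 `Cc1cc(C(=O)c2ccc(F)cc2)ccc1OCC(=O)Nc1nc(-c2ccccc2)cs1` gives 32100 nM in this assay, the highest of the two numbers, but its nearest neighbour compound 1 lies within the scatter of it, so no order between them can be read.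

The step under consideration leads from compound 2 to compound 3 `COc1ccc(-c2csc(NC(=O)COc3ccc(C(=O)c4ccc(F)cc4)cc3C)n2)cc1`, which has not yet been measured in this assay. The change is methoxy in place of hydrogen on an aromatic carbon, para to a large group. Compound 3 thus carries both the methoxy of compound 1 and the fluorine of compound 2.

For the measured compounds named here, with no measured pair showing this change, the size of the step is open. Compound 1, which bears the methoxy, gives 16000 nM, a number on the lower side of the two, so compound 3 is expected to follow it, with a step of a 1.6-fold lower number from compound 2 to compound 3 (0.21 log units; within the scatter) of modest size toward a lower number, likely not beyond the scatter. Compound 3 is therefore estimated at 20000 nM, within a range of 8000 nM to 50000 nM.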

Compound 3, half-maximal inhibitory concentration: 5000 nM
For compound 3 the middle estimate is 4.0-fold (0.60 log units) above the measured one; the measured number lies below the stated range.
By their numbers in this assay, from the lowest: compound 3; then compounds 1 and 2 (each within the scatter of the next).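

In this assay, for the compounds shown here, the change from phenyl to 4-methoxyphenyl, para to a large group, gives a 6.4-fold lower number from compound 2 to compound 3 (0.81 log units; beyond the scatter), the first single change at this place with a step beyond the scatter; compound 1 and compound 2 differ in two places, so neither of the two changes could be read from that pair alone. The second single change, fluoro in place of methyl on an aromatic carbon, gives a 3.2-fold lower number from compound 1 to compound 3 (0.51 log units; beyond the scatter), so with the methoxy present the fluoro compound also stands apart from the methyl compound by more than the scatter. Nothing at hand says why either change moves the number in this cell assay, and the data show only the size and direction of the two steps.

What the compounds shown leave open is whether the methoxy step keeps its size when methyl rather than fluoro is carried on the other aromatic ring. They also leave open whether a hydroxy group, an amine or a longer ether such as ethoxy in place of the methoxy would give a step of similar size, or whether chloro in place of fluoro would do so.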